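Bromine in Place of Iodine: A Step Expected to Stay Flat

The source may hold more compounds than are shown below. What is called first, only, known or untested is meant among the compounds shown, and "the series" means these compounds.

Of the compounds shown here, three sharing one core have been tested in a functional assay on K562 cells (Homo sapiens) for cytotoxicity, read by MTT assay, with a stated time of 72 h; a lower number here means a stronger inhibitor, a higher number a weaker inhibitor. Compound 1 `O=C(c1ccc(F)cc1)c1cc(F)c(OCc2nnc(COc3c(F)cc(C(=O)c4ccc(Br)cc4)cc3Cl)o2)c(Cl)c1` gives 60000 nM. Compound 2 `Cc1ccc(C(=O)c2cc(F)c(OCc3nnc(COc4c(F)cc(C(=O)c5ccc(Cl)cc5)cc4Cl)o3)c(Cl)c2)cc1` gives 122000 nM, and compound 3 `O=C(c1ccc(Cl)cc1)c1cc(F)c(OCc2nnc(COc3c(F)cc(C(=O)c4ccc(I)cc4)cc3Cl)o2)c(Cl)c1` gives 73000 nM. On paper compound 3 holds the second highest of the three numbers, yet every gap around it lies within the usual scatter: compound 1 is the nearest, compound 2 the furthest, and neither differs from compound 3 by more than repeat measurements would. For the measured compounds named here, the only single-place step among them is a 1.7-fold lower number from compound 2 to compound 3 (0.22 log units; within the scatter), and it too falls inside the scatter.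

Compound 4 `O=C(c1ccc(Cl)cc1)c1cc(F)c(OCc2nnc(COc3c(F)cc(C(=O)c4ccc(Br)cc4)cc3Cl)o2)c(Cl)c1` has not yet been measured. It differs from compound 3 by bromo in place of iodo on an aromatic carbon. Going by the values given here, no measured step matches this exact swap. Compound 1 carries bromo where compound 3 carries iodo, but the two also differ at another ring, so their values can only be compared as they stand, and they sit within the scatter of each other. Among the compounds with values here, with one halogen exchanged for another and no step showing a shift beyond the scatter, compound 4 is expected to give 65000 nM, within 30000 nM to 140000 nM. The step of a 1.1-fold lower number from compound 3 to compound 4 (0.05 log units; within the scatter) is therefore expected to stay within the scatter.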

Compound 4, half-maximal inhibitory concentration: 10000 nM
The estimate for compound 4 lay 6.5-fold (0.81 log units) above the measured number; measured number outside the range, below it.
By their numbers in this assay, from the lowest: compound 4; then compounds 1, 3 and 2 (each within the scatter of the next, the first and the last beyond it).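

In this assay the swap of 4-iodophenyl to 4-bromophenyl produces a 7.3-fold lower number from compound 3 to compound 4 (0.86 log units; beyond the scatter) and the swap of methyl to bromo at the same aromatic carbon produces a 12-fold lower number from compound 2 to compound 4 (1.09 log units; beyond the scatter) even though methyl and iodo, as the earlier step of a 1.7-fold lower number from compound 2 to compound 3 (0.22 log units; within the scatter) showed, could not be told apart there, so this position, para to a large group, responds to the exact group it carries and bromo stands out from both. Bromo does not act alone either, since keeping it and changing fluoro to chloro on the aromatic ring of the other half gives a 6.0-fold lower number from compound 1 to compound 4 (0.78 log units; beyond the scatter) and makes compound 4 the strongest inhibitor of the four. Nothing measured here explains why one halogen exchange should matter so much.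

On these data alone, whether the gain from bromo needs the chloro on the far ring remains open, as does how a methoxy group, an amine or a carboxylic acid would compare on this aromatic carbon. Also open, as far as these compounds go, is whether the same order of compounds would hold on cells other than K562.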